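The source may hold more compounds than are shown below. What is called first, only, known or untested is meant among the compounds shown, and "the series" means these compounds.

Measured so far:
- compound 1 `CNC(=O)c1cc(Oc2ccc(NC(=O)c3cc4cccnc4n(-c4ccccc4F)c3=O)cc2)ccn1`: 260 nM in a functional assay on HT-29 cells (Homo sapiens) for antiproliferative activity, read by MTT assay, with a stated time of 72 h; on this read-out higher numbers stand for weaker inhibition and lower numbers for stronger inhibition
- compound 2 `CNC(=O)c1cc(Oc2ccc(NC(=O)c3cc4cccnc4n(-c4ccc(Br)cc4)c3=O)cc2)ccn1`: 1180 nM in this assay
- compound 3 `CNC(=O)c1cc(Oc2ccc(NC(=O)c3cc4cccnc4n(-c4ccc(Br)cc4F)c3=O)cc2)ccn1`: 1950 nM in this assay

Compound 3 holds the highest number of the three, meaning the weakest inhibition seen here; compound 2 is the nearest to it, and the two sit within the scatter of each other, while compound 1 lies clearly lower. Compound 4 `CNC(=O)c1cc(Oc2ccc(NC(=O)c3cc4cccnc4n(-c4ccc(C(F)(F)F)cc4Cl)c3=O)cc2)ccn1` has not yet been measured. It differs from compound 3 in one place: 2-chloro-4-(trifluoromethyl)phenyl in place of 4-bromo-2-fluorophenyl on an aromatic nitrogen.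

Among the measured compounds shown here, three measured steps bear on this change. The step of a 4.5-fold higher number from compound 1 to compound 2 (0.66 log units; beyond the scatter) and the step of a 7.5-fold higher number from compound 1 to compound 3 (0.88 log units; beyond the scatter) both show that putting a bromo group at the 4-position of this phenyl ring weakened inhibition beyond the scatter. The step of a 1.7-fold higher number from compound 2 to compound 3 (0.22 log units; within the scatter), adding a fluoro group, stayed within the scatter. Compound 4 keeps a group at each of those two positions, only larger ones, so a small shift toward a higher number or no step beyond the scatter is expected, shown as a 1.3-fold higher number from compound 3 to compound 4 (0.12 log units; within the scatter). Compound 4 is therefore estimated at 2600 nM, within a range of 900 nM to 7500 nM.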

Compound 4, half-maximal inhibitory concentration: 3190 nM
Compound 4: middle estimate off by 1.2-fold (0.09 log units), on the low side; measured number inside the range.
By their numbers in this assay, from the lowest: compound 1; then compounds 2, 3 and 4 (each within the scatter of the next, the first and the last beyond it).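

In this assay, exchanging the 4-bromo-2-fluorophenyl group for the 2-chloro-4-(trifluoromethyl)phenyl group, which has more heavy atoms, gives a 1.6-fold higher number from compound 3 to compound 4 (0.21 log units; within the scatter), so the larger group does not separate these two compounds. The same group gives a 2.7-fold higher number from compound 2 to compound 4 (0.43 log units; beyond the scatter) when it replaces the 4-bromophenyl group and a 12-fold higher number from compound 1 to compound 4 (1.09 log units; beyond the scatter) when it replaces the 2-fluorophenyl group, the largest step in this set; compound 1, with no bromo or trifluoromethyl group on this ring, stays apart from the other three. No measurement given here explains why these numbers differ.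

From the compounds shown here alone, it remains open whether a different kind of group on this ring, such as an amine or a carboxylic acid, would lower the number. The compounds shown also leave open how a plain phenyl group would compare with the 2-fluorophenyl group of compound 1.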